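A few compounds are considered here, and "the series" means these few. Any claim that something is new, unique, unknown or untested is made for them only; others in the source may bear on it.

Measured compounds:
Compound 1, `Cc1cn(Cc2ccc(Cl)cc2Cl)c2c(-c3nnc(NS(=O)(=O)c4cc(Cl)c(Cl)s4)o3)cc(F)cc12`: 46.4%
Compound 2, `Cc1cn(Cc2ccc(Cl)cc2Cl)c2c(-c3cc(NS(=O)(=O)c4cc(Cl)c(Cl)s4)no3)cc(F)cc12`: 57.8%

In an ADME assay on microsomes from liver (Rattus norvegicus) for metabolic stability, with a stated time of 30 min (on this read-out higher numbers stand for a more stable compound and lower numbers for a less stable compound), compound 1 gives 46.4%, the lower of the two numbers. Compound 2 gives 57.8%, a number higher by more than the scatter. Compound 3, `Cc1cn(Cc2ccc(Cl)cc2Cl)c2c(-c3nnc(NS(=O)(=O)c4ccc(Cl)c(Cl)c4)o3)cc(F)cc12`, has not yet been measured. It differs from compound 1 in one place: 3,4-dichlorophenyl in place of 4,5-dichlorothiophen-2-yl on a sulfonyl sulfur. For the measured compounds named here, no measured pair shows this change, so its size cannot be read from the data. The expected step of a number 1.6 percentage points higher from compound 1 to compound 3 (within the scatter) in this assay is small and not beyond the scatter. For compound 3 the estimate is 48%, in the range 30% to 66%.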

Compound 3, percent of the compound remaining: 44.8%
Estimate against measurement, compound 3: 3.2 percentage points above; the range from low to high includes it.
By their numbers in this assay, from the lowest: compounds 3 and 1 (each within the scatter of the next); then compound 2.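

In this assay, 3,4-dichlorophenyl in place of 4,5-dichlorothiophen-2-yl on a sulfonyl sulfur gives a number 1.6 percentage points lower from compound 1 to compound 3 (within the scatter) and so does not separate the two groups at this position. For the compounds shown here, this is the first pair to differ at the sulfonyl sulfur, and on this core the read-out does not tell the two rings apart. Nothing at hand gives a reason for this result. Open, going by these compounds, is whether the same exchange would read alike on the core of compound 2, and whether a methyl group or a ring bearing a carboxylic acid on that sulfur would stay within the scatter of compound 1.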